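Methoxymethyl in place of hydroxymethyl on the core

A few compounds are considered here, and "the series" means these few. Any claim that something is new, unique, unknown or untested is made for them only; others in the source may bear on it.

Compound 1 `Cc1c(C2CC2)nc2ccc(-n3ccc(OCc4ccc(F)cc4)cc3=O)cn12` gives 28 nM in an assay on CHO cells for displacement of a labelled ligand from melanin-concentrating hormone receptor 1 (Rattus norvegicus), read by scintillation counting, with a stated time of 1 h; a higher number here means a weaker inhibitor, a lower number a stronger inhibitor. Compound 2 `Cc1c(C2CC2)nc2ccc(-n3ccc(OCc4ccc(C(C)C)cc4)cc3=O)cn12` gives 240 nM in this assay. Compound 3 `Cc1c(CO)nc2ccc(-n3ccc(OCc4ccc(F)cc4)cc3=O)cn12` gives > 1000 nM in this assay, which is a limit of the assay and not a number. Compound 3 therefore stands at the limit of > 1000 nM in this assay, at which 1 of the 3 values shown sits, and no number for it is known.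

Compound 4 `COCc1nc2ccc(-n3ccc(OCc4ccc(F)cc4)cc3=O)cn2c1C` differs from compound 3 by methyl in place of hydrogen on an oxygen on a saturated carbon. Two measured steps exist in the series. The step of an 8.6-fold higher number from compound 1 to compound 2 (0.93 log units; beyond the scatter) concerns the other end of the molecule and does not touch the position changed here. Among the compounds with values here, the step of an at least 35-fold higher number from compound 1 to compound 3 (1.55 log units; beyond the scatter) concerns the same position but exchanges the whole group, so it tells only that the hydroxymethyl bearer compound 3 is weak; it does not say how the O-methyl affects this.

Compound 4 is expected to stay close to compound 3, with a step that the limit leaves unreadable from compound 3 to compound 4 in this assay, that is no change beyond the scatter is expected, since compound 3 already gives > 1000 nM and the measured steps give no direction for this change. Compound 4 is estimated at 1500 nM, with a range from 400 nM to 6000 nM, and most likely only a limit will be reported.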

Compound 4, half-maximal inhibitory concentration: > 1000 nM
Compound 4 ended at the assay's limit; the forecaster's own chance of this, stated with the estimate: 60%; the middle value is on the limit's open side.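

In this assay, methoxymethyl in place of cyclopropyl on the core gives an at least 35-fold higher number from compound 1 to compound 4 (1.55 log units; beyond the scatter), so a second group at this position falls well short of compound 1. Compound 4 gives > 1000 nM, which is a limit of the assay, so putting methyl on the oxygen of hydroxymethyl does not bring the value back into the readable range. The step between compound 3 and compound 4 cannot be read, so any effect of the methyl remains hidden, and the two compounds now share a single limit: the limit of > 1000 nM in this assay, at which 2 of the 4 values shown sit.

Cyclopropyl remains the only group at this position with a readable value, so it stays open whether an ethyl, a longer chain without oxygen, an amine or a carboxylic acid there would give a number and how far it would lie from compound 1. As far as these compounds go, it also stays open whether the step at the other end of the molecule, an 8.6-fold higher number from compound 1 to compound 2 (0.93 log units; beyond the scatter), would carry over to compounds with methoxymethyl on the core.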